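Swapping the Chain Amine on a Quinoline Urea

A few compounds are considered here, and "the series" means these few. Any claim that something is new, unique, unknown or untested is made for them only; others in the source may bear on it.

Compound 2, `COc1cc2c(Oc3c(F)cc(NC(=O)NN4C(=O)CSC4c4c(F)cccc4F)cc3F)ccnc2cc1OCCCN1CCCC1`, in a functional assay on HT-29 cells (Homo sapiens) for antiproliferative activity, read by MTT assay, with a stated time of 72 h (on this read-out lower numbers stand for stronger inhibition and higher numbers for weaker inhibition), gives 230 nM.
Compound 1, `COc1cc2c(Oc3ccc(NC(=O)NN4C(=O)CSC4c4c(F)cccc4F)cc3Cl)ccnc2cc1OCCCN1CCCC1`, in this assay gives 480 nM.
Compound 3, `COc1cc2c(Oc3c(F)cc(NC(=O)NN4C(=O)C(C)SC4c4c(F)cccc4F)cc3F)ccnc2cc1OCCCN1CCCC1`, in this assay gives 670 nM.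

Compound 2 gives the lowest number of the three. Compound 1 stands higher, and compound 3 is higher still, by a 2.9-fold higher number from compound 2 to compound 3 (0.46 log units; beyond the scatter), a change made on the saturated ring next to the urea, far from the basic chain amine.

Compound 4, `COc1cc2c(Oc3c(F)cc(NC(=O)NN4C(=O)CSC4c4c(F)cccc4F)cc3F)ccnc2cc1OCCCN1CCc2sccc2C1`, differs from compound 2 by a group of 9 heavy atoms (7 carbon, 1 nitrogen, 1 sulfur; one five-membered aromatic ring with 1 hetero atom, one six-membered non-aromatic ring with 1 hetero atom) in place of a group of 5 heavy atoms (4 carbon, 1 nitrogen; one five-membered non-aromatic ring with 1 hetero atom), on a saturated chain carbon, three bonds along the chain from an oxygen on an aromatic ring. Within the data shown here, none of the measured steps touches this part of the molecule: the single one-place step concerns a methyl on the ring carbon, and the difference between compound 1 and compound 2 lies on the central aromatic ring. There is therefore no measured guide for this swap, and the expectation is that the larger amine changes the number little, most likely within or just beyond the scatter. The estimate for compound 4 in this assay is 320 nM, with a range of 110 nM to 950 nM, which means an expected step of a 1.4-fold higher number from compound 2 to compound 4 (0.14 log units; within the scatter).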

Compound 4, half-maximal inhibitory concentration: 1410 nM
For compound 4 the middle estimate is 4.4-fold (0.64 log units) below the measured one; measured number above the stated range.
By their numbers in this assay, from the lowest: compound 2; then compounds 1 and 3 (each within the scatter of the next); then compound 4.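

The chain amine is not a silent part of these molecules: in this assay, putting the 9-heavy-atom group in place of pyrrolidin-1-yl gives a 6.1-fold higher number from compound 2 to compound 4 (0.79 log units; beyond the scatter). Among these compounds, the earlier one-place step concerned only a methyl on a saturated ring carbon, so this is the first sign that the far end of the chain also moves the number. With one swap at this position, the result cannot separate the effect of the added size from that of the sulfur or the five-membered aromatic ring, and nothing measured here bears on why the number rises.

Still open, going by these compounds, is where piperidine or morpholine, each a single six-membered ring, would fall on the same chain. The compounds shown also leave open whether this swap would give a similar step on compound 1 or compound 3.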